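Chain extension on the aryl alkyl of the shared core

The compounds below may be only part of what the source reports. "The series", "measured", "known", "first", "only" and "open" are said of these compounds alone.

Measured so far in a functional assay on brain (Rattus norvegicus, strain Wistar) for inhibition; a lower number here means a stronger inhibitor, a higher number a weaker inhibitor:
- compound 1 `CCCCc1ccc(-c2c(C)[nH]c(=O)n2C)cc1`: 10700 nM
- compound 2 `CCCCCCCCCCc1ccc(-c2c(C)[nH]c(=O)n2C)cc1`: 7900 nM

Both numbers lie within the scatter of each other; the step of a 1.4-fold lower number from compound 1 to compound 2 (0.13 log units; within the scatter) carries no reading in either direction. Compound 2 therefore stands alongside compound 1, not apart from it.

The next compound, compound 3 `CCCCCCCCCCCCCCCCCCc1ccc(-c2c(C)[nH]c(=O)n2C)cc1`, continues the same line: octyl in place of hydrogen on a saturated chain carbon, ten or more bonds along the chain from an aromatic carbon. Read one bond further out it is methyl to nonyl, or ethyl to decyl.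

Going by the values given here, the only step that bears on this change is a 1.4-fold lower number from compound 1 to compound 2 (0.13 log units; within the scatter), a lengthening of the same chain that left this assay unmoved. Nothing measured speaks to a chain of this length, so the expectation rests on that single flat step. The estimated step of a 1.0-fold higher number from compound 2 to compound 3 (0.01 log units; within the scatter) is therefore expected to be none beyond the scatter, with the range widened because the series has not been followed this far and compound 2 is the only anchor.

Compound 3 is estimated at 8000 nM in this assay, expected between 2500 nM and 30000 nM.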

Compound 3, half-maximal inhibitory concentration: > 100000 nM
Compound 3 ended at the assay's limit; the forecaster's own chance of this, stated with the estimate: 20%; at least 12-fold (1.09 log units) between middle value and limit.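

Compound 3 gives > 100000 nM in this assay, which is a limit of the assay and not a number.

Going by these compounds alone, the chain position is not indifferent to length after all: the lengthening in a 1.4-fold lower number from compound 1 to compound 2 (0.13 log units; within the scatter) left the reading flat, whereas octyl in place of hydrogen on a saturated chain carbon gives an at least 12-fold higher number from compound 2 to compound 3 (1.10 log units; beyond the scatter), the first step to lie beyond the scatter. The size of that step is bounded on one side only, and compound 3 is the sole compound at this ceiling: the limit of > 100000 nM in this assay, at which 1 of the 3 values shown sits.

The compounds shown leave open where, on the way from the decyl chain of compound 2 to the longer chain of compound 3, inhibition is lost, and whether that loss is abrupt or gradual; a dodecyl or a tetradecyl chain would narrow this down. Also open, from the compounds shown here alone, is whether a chain of the same length as in compound 3 that ends in a carboxylic acid or an amine would stay at the limit in this assay or come back into the range of compound 1 and compound 2.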